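This account rests on a few compounds, and the source may have more. Where it says the series, first, only, none or still open, it means among the compounds named here.

In an assay on HEK293 cells for positive allosteric modulation of metabotropic glutamate receptor 3 (Rattus norvegicus), read by thallium flux, with a stated time of 2.5 min (a higher number here means a larger maximal response, a lower number a smaller maximal response), compound 2 `Cc1c(OCCCCOc2ccc(C(=O)O)cc2Cl)ccc(C(=O)CC(C)C)c1O` gives 62.9%, the lower of the two numbers measured, a gap that the step of a number 4.8 percentage points lower from compound 1 to compound 2 (within the scatter) shows to be within the scatter. Compound 1 `Cc1c(OCCCCOc2ccc(C(=O)O)cc2F)ccc(C(=O)CC(C)C)c1O` gives 67.7%. For the measured compounds named here, compound 3 `Cc1ccc(C(=O)O)cc1OCCCCOc1ccc(C(=O)CC(C)C)c(O)c1C` differs from compound 2 in one place: 5-carboxy-2-methylphenyl in place of 4-carboxy-2-chlorophenyl on an oxygen on a saturated carbon The single measured step concerns the same ring but only exchanges one halogen for another, so it says little about a change that also alters the carboxy group's placement and brings in a methyl. No step beyond the scatter is expected, and the estimate for compound 3 is 62%, between 45% and 78%, an expected step of a number 0.9 percentage points lower from compound 2 to compound 3 (within the scatter).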

Compound 3, largest response reached (reported as percent of maximum), in percent of the reference or control that the assay uses: 29.4%
Beside the measured number, compound 3's estimate is 32.6 percentage points above it; measured number outside the range, below it.
By their numbers in this assay, from the lowest: compound 3; then compounds 2 and 1 (each within the scatter of the next).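

At the aryl group on the oxygen, a number 33.5 percentage points lower from compound 2 to compound 3 (beyond the scatter) and a number 38.3 percentage points lower from compound 1 to compound 3 (beyond the scatter) in this assay show that 5-carboxy-2-methylphenyl does not keep the response seen with the two halogen-bearing groups. This position therefore matters for the maximal response, which the exchange of one halogen for another had not shown. Nothing at hand gives a reason for this drop.

The compounds shown leave open whether the placement of the carboxy group or the methyl accounts for the drop, since both change at once. A 4-carboxy-2-methylphenyl group on the same oxygen would separate the two.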